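Trimming the Urea Tail of Compound 1

This account rests on a few compounds, and the source may have more. Where it says the series, first, only, none or still open, it means among the compounds named here.

Compound 1 `C#CCNC(=O)Nc1ccc(-c2nc3n(Cc4c(F)cccc4F)cc(C(=O)OCC)c(=O)n3c2CN(C)Cc2ccccc2)cc1` is measured in a functional assay on CHO cells for antagonist activity at Gonadotropin-releasing hormone receptor (Homo sapiens), read by a luciferase reporter, with a stated time of 30 min (a lower number here means a stronger inhibitor, a higher number a weaker inhibitor), where compound 1 gives 676 nM. Compound 3 `CCNC(=O)Nc1ccc(-c2nc3n(Cc4c(F)cccc4F)cc(C(=O)OCC)c(=O)n3c2CN(CC(=O)NCc2cn(CCOCCOCCN=[N+]=[N-])nn2)Cc2ccccc2)cc1` gives 468 nM in this assay, and the gap between these two numbers lies within the usual scatter of repeated measurements. Compound 2 `CCNC(=O)Nc1ccc(-c2nc3n(Cc4c(F)cccc4F)cc(C(=O)NCc4cn(CCOCCOCCOCCN=[N+]=[N-])nn4)c(=O)n3c2CN(C)Cc2ccccc2)cc1` reaches only a limit in this assay, < 10000 nM, which is the limit (the limit of < 10000 nM in this assay, at which 1 of the 3 values shown sits). Compound 4 `CCNC(=O)Nc1ccc(-c2nc3n(Cc4c(F)cccc4F)cc(C(=O)OCC)c(=O)n3c2CN(C)Cc2ccccc2)cc1` has not yet been measured. It differs from compound 1 in one place: methyl in place of ethynyl on a saturated chain carbon bound to an amide-type nitrogen. Compound 3 already carries the ethylcarbamoyl group and gives 468 nM with it. The step from compound 1 to compound 4 is expected to be small, a 1.4-fold lower number from compound 1 to compound 4 (0.13 log units; within the scatter), with no change beyond the scatter. Compound 4 is estimated at 500 nM, within a range from 200 nM to 1300 nM.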

Compound 4, half-maximal inhibitory concentration: 70.8 nM
Compound 4: the middle estimate sits 7.1-fold (0.85 log units) above what was measured; the whole stated range lies above it.
By their numbers in this assay, from the lowest: compound 4; then compounds 3 and 1 (each within the scatter of the next).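

In this assay, the change from propargylcarbamoyl to ethylcarbamoyl gives a 9.5-fold lower number from compound 1 to compound 4 (0.98 log units; beyond the scatter), so this small edit to the urea tail matters far more than its size suggests. The earlier compounds shown here differ from one another in several places, so they could not isolate the effect of this position alone. Nothing shown here explains why methyl in place of ethynyl has this effect. From the compounds shown here alone, whether propyl, cyclopropyl or a longer chain in place of the ethyl would keep this stronger inhibition remains open.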